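Replacing the Terminal Bicyclic Group on a Diphenylmethyl Piperazine

This account rests on a few compounds, and the source may have more. Where it says the series, first, only, none or still open, it means among the compounds named here.

Of the compounds shown here, three have so far been measured in an assay on RPMI-8226 cells for antagonist activity at P2X purinoceptor 7 (Homo sapiens), read by calcium flux; on this read-out lower numbers stand for stronger inhibition and higher numbers for weaker inhibition. Compound 1 `O=C(C(c1ccccc1)c1ccccc1)N1CCN(CCCn2c(=O)[nH]c3ccccc32)CC1` gives 7800 nM. Compound 2 `O=c1[nH]c2ccccc2n1CCCN1CCC(C(O)(c2ccccc2)c2ccccc2)CC1` gives 7500 nM. Compound 3 `O=c1[nH]c2ccccc2n1CCCCN1CCN(C(c2ccccc2)c2ccccc2)CC1` gives 180 nM, the lowest of the three numbers, and its separation from compound 2 and from compound 1 lies beyond the usual scatter in each case, so compound 3 is the strongest inhibitor among the three.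

Compound 4 `COc1ccc2c(ccn2CCCCN2CCN(C(c3ccccc3)c3ccccc3)CC2)c1` is the next compound and has not yet been measured. It differs from compound 3 by a group of 11 heavy atoms (9 carbon, 1 nitrogen, 1 oxygen; one five-membered aromatic ring with 1 hetero atom, one six-membered aromatic ring of carbon only) in place of a group of 10 heavy atoms (7 carbon, 2 nitrogen, 1 oxygen; one five-membered aromatic ring with 2 hetero atoms, one six-membered aromatic ring of carbon only), on a saturated chain carbon, four bonds along the chain from an amine nitrogen in a ring. Among the measured compounds shown here, no measured pair in this set shows an exchange of this kind, so the data give no direct measure of its effect; the departing group carries a hydrogen-bond donor and the entering group none, as the count shows, while the rest of the molecule is unchanged. On that basis a moderate step toward weaker inhibition is expected, a 3.3-fold higher number from compound 3 to compound 4 (0.52 log units; beyond the scatter), with a real chance that it stays within the scatter. Compound 4 is therefore estimated at 600 nM, with a range from 150 nM to 3000 nM.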

Compound 4, half-maximal inhibitory concentration: > 10000 nM
Compound 4: a limit, no number (the forecaster's own chance of this, stated with the estimate: 10%); middle value at least 16-fold (1.22 log units) away from the limit.
By their numbers in this assay, from the lowest: compound 3; then compounds 2 and 1 (each within the scatter of the next). At a limit, above all of these: compound 4.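

In this assay, among the compounds shown here, placing 5-methoxy-1H-indol-1-yl in place of the departing group, on a saturated chain carbon, four bonds along the chain from an amine nitrogen in a ring, gives an at least 55-fold higher number from compound 3 to compound 4 (1.74 log units; beyond the scatter) and thus shows that activity depends strongly on the group at this place, which the earlier compounds could not show. Compound 4 carries a limit of the assay and not a number: the limit of > 10000 nM in this assay, at which 1 of the 4 values shown sits. The exchange alters several things at once, for the departing group carries a hydrogen-bond donor and the entering group none, the ring with two hetero atoms gives way to one with a single hetero atom, the carbonyl goes, and a methoxy group arrives, so this single step cannot assign the loss to any one of these changes.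

The compounds shown leave open whether a plain indol-1-yl group without the methoxy would behave as compound 4 does, and so whether the methoxy group or the ring exchange carries the step. They also leave open whether a methyl group on the ring nitrogen of the departing group, which would remove the donor and keep the ring, would give a comparable step from compound 3.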